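The compounds below may be only part of what the source reports. "The series", "measured", "known", "first", "only" and "open" are said of these compounds alone.

Measured so far in an ADME assay on a cell-free system (plasma, Mus musculus) for protein binding:
compound 1 `Nc1nccc(N2CC[C@H](NC(=O)Nc3ccc(Cl)c(C(F)(F)F)c3)C2)n1` gives 99.4%
compound 2 `CNc1nccc(N2CC[C@H](NC(=O)Nc3ccc(CN(C)C)c(C(F)(F)F)c3)C2)n1` gives 87.8%
compound 3 `CNc1nccc(N2CC[C@H](NC(=O)Nc3ccc(C)c(Cl)c3)C2)n1` gives 98.6%

Among these three, compound 2 leaves the largest unbound fraction; its distance from compound 3 and from compound 1 lies beyond the scatter in both cases, so compound 2 stands apart as the least bound of the set.

Compound 4 `CNc1nccc(N2CC[C@H](NC(=O)Nc3ccc(CN4CCCC4)c(C(F)(F)F)c3)C2)n1` differs from compound 2 in one place: pyrrolidin-1-yl in place of dimethylamino on a saturated chain carbon bound to an aromatic carbon. Among the measured compounds shown here, no measured pair shows this particular change, so the expectation rests on compound 2 alone. In this assay the step a 1.4-fold lower unbound fraction from compound 2 to compound 4 (0.13 log units; within the scatter) is expected to be small, toward slightly more binding, and within the scatter. Compound 4 is therefore estimated at 91%, with a range from 84% to 96%.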

Compound 4, plasma protein binding: 87.2%
Compound 4: the middle estimate sits 1.4-fold (0.15 log units) (unbound fraction) below what was measured; measured number inside the range.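

In this assay, pyrrolidin-1-yl in place of dimethylamino on the saturated chain carbon bound to an aromatic carbon gives a 1.0-fold higher unbound fraction from compound 2 to compound 4 (0.02 log units; within the scatter). Among the compounds shown here, this is the first pair here that differs in one place, and it shows that a five-membered non-aromatic ring can stand at this position with no readable shift in binding. Nothing available here bears on the reason for this result.

Going by these compounds, how this assay responds at this place to a morpholin-4-yl, or to a chain ending in a carboxylic acid, stays open.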